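A few compounds are considered here, and "the series" means these few. Any claim that something is new, unique, unknown or untested is made for them only; others in the source may bear on it.

Working notes on the series.

Within the data shown here, compound 3 `O=C(O)c1ccccc1-c1ccc(CCc2ncc(CCc3ccccc3)[nH]2)cc1` stands highest of the three numbers so far: in an in vitro functional assay on cells for agonist activity at Bombesin receptor subtype-3 (Homo sapiens), read by luminescence and calcium flux (on this read-out higher numbers stand for an effect only at larger amounts of compound and lower numbers for an effect already at smaller amounts), compound 3 gives 1320 nM. Compound 1 `O=C(O)c1ccccc1-c1ccc(CCc2ncc(CC3CCC3)[nH]2)cc1` gives 588 nM and compound 2 `O=C(O)c1ccccc1-c1ccc(CCc2ncc(CC3CCOCC3)[nH]2)cc1` gives 338 nM. The measured steps all concern the group on the saturated chain carbon bound to an aromatic carbon: a 1.7-fold lower number from compound 1 to compound 2 (0.24 log units; within the scatter), a 2.2-fold higher number from compound 1 to compound 3 (0.35 log units; beyond the scatter), and a 3.9-fold higher number from compound 2 to compound 3 (0.59 log units; beyond the scatter).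

Compound 4 `CC(C)(C)c1cnc(CCc2ccc(-c3ccccc3C(=O)O)cc2)[nH]1` differs from compound 3 as follows: tert-butyl in place of phenethyl on an aromatic carbon. The group that leaves carries the six-membered aromatic ring of carbon only; the group that enters has no ring. The direct steps bear on this only loosely, since they replace the group on a chain carbon rather than on the aromatic carbon. Still, both groups without an aromatic ring, in compound 1 and compound 2, sit at lower numbers than compound 3, so a modest step down is expected for compound 4, a 2.9-fold lower number from compound 3 to compound 4 (0.47 log units; beyond the scatter). Compound 4 is expected to give about 450 nM in this assay, estimated between 180 nM and 1200 nM.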

Compound 4, half-maximal effective concentration: 4330 nM
Beside the measured number, compound 4's estimate is 9.6-fold (0.98 log units) below it, outside the stated range (above it).
By their numbers in this assay, from the lowest: compounds 2 and 1 (each within the scatter of the next); then compound 3; then compound 4.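

The tert-butyl group on this aromatic carbon gives the highest number of the four in this assay, with a 3.3-fold higher number from compound 3 to compound 4 (0.52 log units; beyond the scatter), a 7.4-fold higher number from compound 1 to compound 4 (0.87 log units; beyond the scatter) and a 13-fold higher number from compound 2 to compound 4 (1.11 log units; beyond the scatter). Compound 1 and compound 2 sit at lower numbers than compound 3 without an aromatic ring in the group at this position, but compound 4, also without one, goes against that pattern, so losing the six-membered aromatic ring does not by itself bring the number down. Nothing in the data given accounts for the rise in compound 4.

Going by these compounds, whether the number follows the branching of tert-butyl or the smaller group as such stays open. An isobutyl group, a neopentyl group or a straight butyl chain on the same aromatic carbon would separate the two readings.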